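The source may report more compounds than this note shows. Statements on the series, on what has been measured and on what is new or still open speak of the compounds shown alone.

Measured compounds:
compound 1, `COc1cc2c(Oc3ccc(NC(=O)c4nnn(-c5ccc(F)cc5)c4C(F)(F)F)cc3F)ccnc2cc1OCCCN1CCCC1`: 150 nM
compound 2, `COc1cc2c(Oc3ccc(NC(=O)c4nnn(-c5ccccc5C(F)(F)F)c4C(F)(F)F)cc3F)ccnc2cc1OCCCN1CCCC1`: 270 nM
compound 3, `COc1cc2c(Oc3ccc(NC(=O)c4nnn(-c5ccc(F)cc5)c4C(F)(F)F)cc3F)ccnc2cc1OCCCN1CCCCC1`: 190 nM

All three were run in a functional assay on NCI-H460 cells (Homo sapiens) for cytotoxicity, read by MTT assay, with a stated time of 72 h; a lower number here means a stronger inhibitor, a higher number a weaker inhibitor. Compound 3 sits within the scatter of both others: a 1.3-fold higher number from compound 1 to compound 3 (0.10 log units; within the scatter), and its value against compound 2 also lies within the scatter. Compound 4, `COc1cc2c(Oc3ccc(NC(=O)c4nnn(-c5ccc(F)c(F)c5)c4C(F)(F)F)cc3F)ccnc2cc1OCCCN1CCCCC1`, is not yet measured in this assay; it differs from compound 3 by fluoro in place of hydrogen on an aromatic carbon. For the measured compounds named here, no measured step adds a fluoro to this aromatic ring. Going by the values given here, the one change made on that ring, a 1.8-fold higher number from compound 1 to compound 2 (0.26 log units; within the scatter), stayed within the scatter, as did the change on the saturated chain, a 1.3-fold higher number from compound 1 to compound 3 (0.10 log units; within the scatter). A step no larger than the scatter is therefore expected, a 1.1-fold higher number from compound 3 to compound 4 (0.02 log units; within the scatter). Compound 4 is estimated at 200 nM in this assay, with a range from 100 nM to 400 nM.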

Compound 4, half-maximal inhibitory concentration: 210 nM
The estimate for compound 4 lay 1.1-fold (0.02 log units) below the measured number; the measured number falls inside the stated range.
By their numbers in this assay, from the lowest: compounds 1, 3, 4 and 2 (each within the scatter of the next).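

In this assay, going from 4-fluorophenyl to 3,4-difluorophenyl gives a 1.1-fold higher number from compound 3 to compound 4 (0.04 log units; within the scatter), the only step shown that adds a fluoro to this aromatic ring. A second fluoro at this carbon, ortho to a fluoro group, therefore leaves the number within the scatter, though this rests on a single pair with piperidin-1-yl on the chain. No supporting measurement bears on the size of this step. Open, going by these compounds, is whether a methoxy, an amine or a carboxylic acid on this carbon would also stay within the scatter. Also open, on these data alone, is whether the same fluoro gives a similar step with pyrrolidin-1-yl on the chain.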